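A few compounds are considered here, and "the series" means these few. Any claim that something is new, unique, unknown or untested is made for them only; others in the source may bear on it.

Measured compounds:
- compound 1, `Oc1cccc(-c2cc(-c3ccccn3)nc(-c3ccccc3Cl)c2)c1`: "not determined" (no result reported)
- compound 2, `Oc1ccc(-c2cc(-c3ccccc3)nc(-c3ccc(Cl)cc3)c2)cc1`: 4270 nM
- compound 3, `Oc1ccc(-c2cc(-c3ccc(Cl)cc3)nc(-c3ccccn3)c2)cc1`: 25900 nM

Three compounds share a core carrying a hydroxyphenyl group, a chlorophenyl group and a third aromatic ring, and were tested in a functional assay on T47D cells (Homo sapiens) for cytotoxicity, read by CCK-8 assay and cell counting, with a stated time of 2 days; a lower number here means a stronger inhibitor, a higher number a weaker inhibitor. Compound 1 has no number here. Compound 2 gives 4270 nM in this assay, and compound 3 gives 25900 nM.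

Compounds 2 and 3 differ in one place: phenyl in place of pyridin-2-yl on an aromatic carbon. This change gives a 6.1-fold lower number from compound 3 to compound 2 (0.78 log units; beyond the scatter), a clear gain in potency.

The unmeasured compound 4, `Oc1cccc(-c2cc(-c3ccccc3)nc(-c3ccccc3Cl)c2)c1`, stands in the same relation to compound 1: phenyl in place of pyridin-2-yl on an aromatic carbon. The two changes are of the same kind, not the same, for the surroundings differ. In compound 3 the change sits meta to a 4-chlorophenyl group and meta to a 4-hydroxyphenyl group; in compound 1 it sits meta to a 2-chlorophenyl group and meta to a 3-hydroxyphenyl group. Compounds 1 and 3 contain the same atoms joined differently, and the difference between the two cores is not broken down here.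

With no number for compound 1, the step from compound 1 to compound 4 cannot be sized; the expectation for compound 4 rests on compound 2, which gives 4270 nM in this assay and carries the same phenyl and the same pattern of groups, only placed differently. Compound 4 is therefore estimated at 6000 nM, in a range from 1500 nM to 30000 nM, with wide uncertainty.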

Compound 4, half-maximal inhibitory concentration: 2920 nM
Compound 4: middle estimate off by 2.1-fold (0.31 log units), on the high side, and the stated range covers the measured number.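

Within the data shown here, compound 1 has no number in this assay, so no step from compound 1 to compound 4 can be read from the new result. No measurement shown here offers an explanation for the value of compound 4. The compounds shown leave open whether phenyl in place of pyridin-2-yl on the core of compound 1 brings anything like a 6.1-fold lower number from compound 3 to compound 2 (0.78 log units; beyond the scatter).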